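Swapping fluoro for chloro: what size of step?

The source may hold more compounds than are shown below. What is called first, only, known or untested is meant among the compounds shown, and "the series" means these compounds.

compound 1 `O=C1/C(=C/c2cccc(Br)c2)CCCc2ccccc21` gives 17100 nM
compound 2 `O=C1CCCCC/C1=C\c1ccccc1` gives 215000 nM
compound 3 `O=C1CCCCC/C1=C\c1ccc(F)cc1` gives 250000 nM

In a functional assay on MOLT-4 cells (Homo sapiens) for inhibition (on this read-out lower numbers stand for stronger inhibition and higher numbers for weaker inhibition), compound 3 lies within the scatter of compound 2, the ordinary spread between repeat measurements. Both numbers stand well above that of compound 1, which has a different core. The next molecule, compound 4 `O=C1CCCCC/C1=C\c1ccc(Cl)cc1`, carries chloro in place of fluoro on an aromatic carbon. For the measured compounds named here, no measured pair shows this exact swap. The closest evidence is a 1.2-fold higher number from compound 2 to compound 3 (0.07 log units; within the scatter) for fluoro in place of hydrogen, a step within the scatter. Compound 1 at 17100 nM carries a bromo, but its core differs too, and it cannot show what a single swap of this kind does. No step beyond the scatter is therefore expected, at most a slight drift towards a lower number. The expected step is a 1.5-fold lower number from compound 3 to compound 4 (0.17 log units; within the scatter) in this read-out. The estimate for compound 4 is 170000 nM as a middle value, with an expected range from 70000 nM to 320000 nM in repeated measurements.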

Compound 4, half-maximal inhibitory concentration: 52600 nM
Compound 4: middle estimate off by 3.2-fold (0.51 log units), on the high side, and the stated range ends above it.
By their numbers in this assay, from the lowest: compound 1; then compound 4; then compounds 2 and 3 (each within the scatter of the next).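

In this assay this spot on the aromatic ring, para to a group of 9 heavy atoms, proves responsive to the group placed there: chloro in place of fluoro gives a 4.8-fold lower number from compound 3 to compound 4 (0.68 log units; beyond the scatter) and so moves the number beyond the scatter, while fluoro in place of hydrogen gave only a 1.2-fold higher number from compound 2 to compound 3 (0.07 log units; within the scatter) and stayed within it. Chloro in place of hydrogen gives a 4.1-fold lower number from compound 2 to compound 4 (0.61 log units; beyond the scatter) as well, so among these three compounds only chloro shifts the number, and the two halogens cannot be treated as interchangeable here. Nothing available explains why chloro and fluoro differ at this spot.

As far as these compounds go, it remains open whether bromo, a methoxy group or an amine at this same spot on the shared core would push the number lower still or bring it back up. Compound 1 carries a bromo, but its different core keeps it from answering that.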